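Working notes: butoxy to 2-ethylbutoxy on the shared core

This account rests on a few compounds, and the source may have more. Where it says the series, first, only, none or still open, it means among the compounds named here.

Measured in a functional assay on NCI-H23 cells (Homo sapiens) for antiproliferative activity, read by sulforhodamine B assay; on this read-out lower numbers stand for stronger inhibition of growth and higher numbers for weaker inhibition of growth:
- compound 1 `CC(C)CCCOc1cccc(O)c1C(=O)/C=C/c1ccc(O)cc1`: 11400 nM
- compound 2 `O=C(/C=C/c1ccc(O)cc1)c1c(O)cccc1OCCC1CCCCC1`: > 30000 nM (a limit)
- compound 3 `CCCCOc1cccc(O)c1C(=O)/C=C/c1ccc(O)cc1`: > 30000 nM (a limit)

Compound 3 sits at the limit of > 30000 nM in this assay, at which 2 of the 3 values shown sit, so the starting point here is a limit and not a number. Compound 4 `CCC(CC)COc1cccc(O)c1C(=O)/C=C/c1ccc(O)cc1` differs from it as follows: ethyl in place of hydrogen on a saturated chain carbon bound to two saturated chain carbons. The same difference reads butyl to 2-ethylbutyl.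

For the measured compounds named here, two measured steps bear on this change, and both start from compound 1, the only compound here with a number. The first is an at least 2.6-fold higher number from compound 1 to compound 3 (0.42 log units; beyond the scatter). Read backwards, it suggests that extra carbon on the butyl chain can bring the number down. The second is an at least 2.6-fold higher number from compound 1 to compound 2 (0.42 log units; beyond the scatter), which shows that a larger chain end does not necessarily keep that gain. The remaining step, a step that the two limits leave unreadable from compound 2 to compound 3, adds nothing. Neither informative step is the same change as this one, so the expectation is loose.

Given an at least 2.6-fold higher number from compound 1 to compound 3 (0.42 log units; beyond the scatter), a modest move towards lower numbers in this assay is expected, though compound 4 may well remain at the limit. The expected step is an at least 1.5-fold lower number from compound 3 to compound 4 (0.17 log units; that floor lies within the scatter). For compound 4 the estimated value is 20000 nM, with an expected range of 9000 nM to 40000 nM.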

Compound 4, concentration for 50% growth inhibition: 3210 nM
The estimate for compound 4 lay 6.2-fold (0.79 log units) above the measured number, and the stated range ends above it.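

In this assay, ethyl in place of hydrogen on a saturated chain carbon bound to two saturated chain carbons gives an at least 9.3-fold lower number from compound 3 to compound 4 (0.97 log units; beyond the scatter); that step starts from a limit, so its full size stays unread. For the compounds shown here, the 2-ethylbutoxy chain also stands apart from the other chains on the shared core: pentan-3-yl in place of cyclohexylmethyl gives an at least 9.3-fold lower number from compound 2 to compound 4 (0.97 log units; beyond the scatter), again starting from a limit, and pentan-3-yl in place of isopentyl gives a 3.6-fold lower number from compound 1 to compound 4 (0.55 log units; beyond the scatter), the only one of these steps read between two numbers. Compound 4 is therefore the most potent of the four here, and added carbon alone does not set the order, since compound 2 goes against that reading.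

Going by these compounds, compound 2 and compound 3 each remain a limit and not a number, which leaves their distance from the other compounds only partly read: the limit of > 30000 nM in this assay, at which 2 of the 4 values shown sit. Whether the gain at this chain carbon holds with propyl in place of ethyl, with a longer chain, or with an amine on the chain stays open.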